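Swapping methyl for chloro on the aryl ring

This account rests on a few compounds, and the source may have more. Where it says the series, first, only, none or still open, it means among the compounds named here.

Among the compounds with values here, compound 2 `Cc1ccc(C2CNN=C2S(=O)(=O)CC2=NCCO2)cc1` has the higher of the two numbers so far in a functional assay, tested at 100 ug/mL (on this read-out lower numbers stand for a weaker effect and higher numbers for a stronger effect at the one concentration tested), giving 46.8%. Within the data shown here, its nearest neighbour is compound 1 `Cc1ccc(C2CNN=C2S(=O)(=O)CC2=NCCS2)cc1`, which in this assay gives 45.1%; the only measured step, a number 1.7 percentage points higher from compound 1 to compound 2 (within the scatter), lies within the scatter. Among the measured compounds shown here, a third compound, compound 3 `O=S(=O)(CC1=NCCS1)c1n[nH]cc1-c1ccccc1`, is reported in this assay as "not active" (no number reported), without a number, and it differs from the others in more than one place, so no single step can be drawn from it.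

Compound 4 `O=S(=O)(CC1=NCCO1)C1=NNCC1c1ccc(Cl)cc1` differs from compound 2 in one place: chloro in place of methyl on an aromatic carbon. For the measured compounds named here, no measured step touches this position; the one known step, from compound 1 to compound 2, concerns the five-membered ring on the other side of the sulfonyl group and stayed within the scatter. There is therefore nothing in these data that points to a shift either way, and the expectation for compound 4 is a step of about a number 1.8 percentage points lower from compound 2 to compound 4 (within the scatter), that is, no change beyond the scatter. Compound 4 is thus estimated at 45%, with a range from 25% to 65%.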

Compound 4, a percentage reported as activity, at one concentration (the size of the read-out at that concentration, not a potency): "not active" (no number reported)
Nothing numeric was reported for compound 4, so the estimate cannot be set against anything.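

In this assay, within the data shown here, compound 4 gives "not active" (no number reported) and carries no number, so no step from compound 2 can be read. The compounds shown leave open whether 4-chlorophenyl in place of 4-methylphenyl shifts the read-out at all. No other data shown here bear on this result.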